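The source may report more compounds than this note shows. Statements on the series, on what has been measured and on what is new or still open speak of the compounds shown alone.

Compound 1 `COC(=O)[C@@]1(C)C[C@@H](c2coc3ccc(Br)cc3c2=O)N(c2ccccc2)O1`: 14700 nM
Compound 2 `COC(=O)[C@H]1C[C@@H](c2coc3ccccc3c2=O)N(c2ccccc2)O1`: > 60000 nM

Both results come from a functional assay on THP-1 cells (Homo sapiens) for inhibition, read by sulforhodamine B assay, with a stated time of 48 h; a lower number here means a stronger inhibitor, a higher number a weaker inhibitor. Compound 1 gives a measured number, 14700 nM, but it differs from compound 2 in more than one place, so no single change can be read from this pair.

Compound 2 gives no exact number. Its > 60000 nM is a limit of the assay.

Compound 3 `CCO[C@H]1C[C@@H](c2coc3ccccc3c2=O)N(c2ccccc2)O1` has ethoxy in place of methoxycarbonyl on a saturated ring carbon, next to the ring oxygen: ethoxy in place of methoxycarbonyl on a saturated ring carbon. For the measured compounds named here, no measured step shows what this change does, so no shift beyond the usual scatter is expected in this assay, and the result may again be only a limit. The expected move is a number no higher from compound 2 to compound 3 (the limit leaves the size open). For compound 3 the estimated value is 60000 nM, with an expected range of 20000 nM to 120000 nM.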

Compound 3, half-maximal inhibitory concentration: > 60000 nM
Compound 3 was reported as a limit; the forecaster's own chance of this, stated with the estimate: 60%; the middle value lies on the limit itself.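

No step can be read from compound 2 to compound 3, because each result is a limit of the assay and not an exact number: the limit of > 60000 nM in this assay, at which 2 of the 3 values shown sit.

The compounds shown leave open whether ethoxy in place of methoxycarbonyl on a saturated ring carbon changes inhibition at all, and in which direction.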